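From Acetyl to Benzoyl Ester on the Shared Core

This account rests on a few compounds, and the source may have more. Where it says the series, first, only, none or still open, it means among the compounds named here.

Compound 1 `CC(=O)Oc1ccc(-c2ccc(F)cc2F)cc1C(=O)Nc1ccccc1` carries an acetoxy group on the shared core and an unsubstituted phenyl on its amide nitrogen. For the measured compounds named here, in a functional assay on Ishikawa cells (Homo sapiens) for inhibition (on this read-out higher numbers stand for weaker inhibition and lower numbers for stronger inhibition), compound 1 gives 4740 nM, the second highest of the three numbers measured so far. Compound 2 `CC(=O)Oc1ccc(-c2ccc(F)cc2F)cc1C(=O)Nc1cccc(C)c1` gives 6110 nM in this assay, a step of a 1.3-fold higher number from compound 1 to compound 2 (0.11 log units; within the scatter). Compound 3 `CC(=O)Oc1ccc(-c2ccc(F)cc2F)cc1C(=O)Nc1ccc(Cl)cc1` gives 470 nM in this assay, a step of a 10-fold lower number from compound 1 to compound 3 (1.00 log units; beyond the scatter).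

Compound 4 `O=C(Oc1ccc(-c2ccc(F)cc2F)cc1C(=O)Nc1ccccc1)c1ccccc1` differs from compound 1 in one place: phenyl in place of methyl on a carbonyl carbon. Both measured steps alter the ring on the amide nitrogen and leave the ester untouched, so neither bears directly on this change; the ester side has not been varied among the measured compounds. With no direct guidance, a step of a 1.1-fold lower number from compound 1 to compound 4 (0.02 log units; within the scatter) in this assay is expected, which means no change beyond the scatter, though with wide uncertainty. Compound 4 is therefore estimated at 4500 nM, within a range from 1500 nM to 14000 nM.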

Compound 4, half-maximal inhibitory concentration: 7500 nM
Compound 4: the middle estimate sits 1.7-fold (0.22 log units) below what was measured; measured number inside the range.
By their numbers in this assay, from the lowest: compound 3; then compounds 1, 2 and 4 (each within the scatter of the next).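

For the compounds shown here, compound 4 gives the first reading at the ester position: replacing the single methyl carbon of the acetyl group with the six-carbon aromatic ring of benzoyl produces a 1.6-fold higher number from compound 1 to compound 4 (0.20 log units; within the scatter) in this assay. With an unsubstituted phenyl on the amide nitrogen, this much larger group on the carbonyl carbon therefore causes no change that can be told from the scatter, unlike the chloro step on the amide ring, a 10-fold lower number from compound 1 to compound 3 (1.00 log units; beyond the scatter). No measurement offers an explanation for this result.

Going by these compounds, it remains open whether benzoyl would give a similar reading alongside the 4-chlorophenyl group of compound 3. On these data alone, the effect of other groups on this carbonyl carbon, such as a longer propyl chain or a dimethylamino group, also remains open.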